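Propoxy in place of methoxy on compound 2

A few compounds are considered here, and "the series" means these few. Any claim that something is new, unique, unknown or untested is made for them only; others in the source may bear on it.

In a functional assay on the whole organism (strain Sprague-Dawley) for inhibition, with Rattus norvegicus as the target, with a stated time of 10 min (on this read-out higher numbers stand for an effect only at larger amounts of compound and lower numbers for an effect already at smaller amounts), compound 2 (`COc1ccc(OC)c(-c2ncc(C(=O)O)c(=O)[nH]2)c1`) gives 1 mg/kg and compound 1 (`CCCOc1ccccc1-c1ncc(C(=O)O)c(=O)[nH]1`) gives 0.9 mg/kg, so the two numbers lie within the scatter of each other. Compound 3 (`CCCOc1ccc(OC)cc1-c1ncc(C(=O)O)c(=O)[nH]1`) arises from compound 2 by ethyl in place of hydrogen on a saturated chain carbon bound to an oxygen on an aromatic ring, or methoxy to propoxy. For the measured compounds named here, no measured step shows this change. Compound 1, which also carries propoxy, stands at 0.9 mg/kg, so only a small move toward lower numbers is expected. The expected change is a 1.7-fold lower number from compound 2 to compound 3 (0.22 log units; within the scatter). Compound 3 is estimated at 0.6 mg/kg, within 0.2 mg/kg to 1.5 mg/kg.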

Compound 3, dose for 50% inhibition: 0.3 mg/kg
For compound 3 the middle estimate is 2.0-fold (0.30 log units) above the measured one; measured number inside the range.
By their numbers in this assay, from the lowest: compound 3; then compounds 1 and 2 (each within the scatter of the next).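

In this assay, lengthening methoxy to propoxy at this position gives a 3.3-fold lower number from compound 2 to compound 3 (0.52 log units; beyond the scatter), so the chain length here counts once the second methoxy is present. Adding methoxy on an aromatic carbon to the propoxy compound gives a 3.0-fold lower number from compound 1 to compound 3 (0.48 log units; beyond the scatter), so the two groups together give the lowest number in the series, and each step lies beyond the scatter. Nothing measured here gives a reason for either step.

From the compounds shown here alone, whether a longer chain such as butoxy lowers the number further remains open. So does how an amine at the end of the propoxy chain would read.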